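The source may hold more compounds than are shown below. What is called first, only, known or untested is meant among the compounds shown, and "the series" means these compounds.

Measured so far in an ADME assay on microsomes from liver (Homo sapiens) for metabolic stability, tested at 2.5 uM; a lower number here means slower removal, a higher number faster removal of the compound:
Compound 1 `O=S(=O)(c1cc(Cl)cc(Cl)c1)c1cnc2cc(F)ccc2c1-c1cccc(F)c1` gives 0.41 mL/min.
Compound 2 `COc1ccc(-c2c(S(=O)(=O)c3ccc(F)c(Cl)c3)cnc3cc(F)ccc23)cc1` gives 1.08 mL/min.

Compound 2 has the higher of these two numbers; compound 1 sits well below it, beyond the usual scatter. Compound 3 `O=S(=O)(c1ccc(F)c(Cl)c1)c1cnc2cc(F)ccc2c1-c1cccc(F)c1` has not been measured. It differs from compound 2 in one place: 3-fluorophenyl in place of 4-methoxyphenyl on an aromatic carbon. The entering 3-fluorophenyl is the same group compound 1 carries on the shared core, while the rest of compound 3 matches compound 2. Among the compounds with values here, no measured pair shows this single change directly, so the step is estimated from where compound 1 and compound 2 stand. Compound 3 is expected to land between them, with a modest drop of a 1.7-fold lower number from compound 2 to compound 3 (0.22 log units; within the scatter) in this assay that may still fall within the scatter. The estimate for compound 3 is 0.65 mL/min, with a range of 0.3 mL/min to 1.3 mL/min.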

Compound 3, intrinsic clearance in a liver preparation (reported as CLH), per the amount of preparation that the assay uses: 0.25 mL/min
For compound 3 the middle estimate is 2.6-fold (0.41 log units) above the measured one, outside the stated range (below it).
By their numbers in this assay, from the lowest: compounds 3 and 1 (each within the scatter of the next); then compound 2.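

In this assay, within the data shown here, 3-fluorophenyl in place of 4-methoxyphenyl on this aromatic carbon gives the first direct reading of a change at this position (a 4.3-fold lower number from compound 2 to compound 3 (0.64 log units; beyond the scatter)). At the sulfonyl sulfur, 3-chloro-4-fluorophenyl and 3,5-dichlorophenyl cannot be told apart (a 1.6-fold lower number from compound 1 to compound 3 (0.21 log units; within the scatter)). The data offer no explanation for either result. From the compounds shown here alone, it remains open whether the step comes from losing the methoxy group or from adding the fluorine. Also open, going by these compounds, is how a phenyl ring carrying an amine or a carboxylic acid would behave at this position.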